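A few compounds are considered here, and "the series" means these few. Any claim that something is new, unique, unknown or untested is made for them only; others in the source may bear on it.

Working notes on the series. Two compounds carry numbers in an ADME assay on Caco-2 cells (Homo sapiens) for permeability, read by LC-MS, in the apical to basolateral direction, with a stated time of 90 min; on this read-out higher numbers stand for higher permeability and lower numbers for lower permeability. Compound 1 `Cc1cc(-n2nccn2)cc(C(=O)NNS(=O)(=O)c2ccccc2)c1F` gives 53 10^-6 cm/s in this assay. Compound 2 `O=C(NNS(=O)(=O)c1ccccc1F)c1cccc(-c2ccco2)c1` gives 55.3 10^-6 cm/s in this assay. The two numbers stand within the scatter of each other, so compound 1 cannot be set apart from compound 2 on these data; it simply sits at the same level. Within the data shown here, no step between measured compounds is available, as the two differ in more than one place.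

Compound 3 `Cc1cc(-c2ncccn2)cc(C(=O)NNS(=O)(=O)c2ccccc2)c1F` is not yet measured. Relative to compound 1 the change is pyrimidin-2-yl in place of 2H-1,2,3-triazol-2-yl on an aromatic carbon. Both rings counted there are aromatic, neither carries a hydrogen-bond donor, and the rest of the structure is unchanged. Among the measured compounds shown here, no measured pair shows this change, so the expectation rests on the level of compound 1 alone. The step from compound 1 to compound 3 in this assay is expected to be none beyond the scatter, a 1.1-fold lower number from compound 1 to compound 3 (0.03 log units; within the scatter). For compound 3 the estimate in this assay is 50 10^-6 cm/s, with a range from 28 10^-6 cm/s to 80 10^-6 cm/s.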

Compound 3, apparent permeability in the Caco-2 assay: 77 10^-6 cm/s
Estimate against measurement, compound 3: 1.5-fold (0.19 log units) below; low and high end bracket the measured number.
By their numbers in the Caco-2 assay, from the lowest: compounds 1, 2 and 3 (each within the scatter of the next).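

Among these compounds, in the Caco-2 assay the first measured pair at this position, meta to a methyl group and para to a fluoro group, shows pyrimidin-2-yl in place of 2H-1,2,3-triazol-2-yl with a 1.5-fold higher number from compound 1 to compound 3 (0.16 log units; within the scatter) on the shared core, so the swap of these two aromatic rings gives no step that can be told from the scatter. In a physicochemical assay for solubility, read by nephelometry, in phosphate buffer, measured as kinetic solubility, at pH 6.5 (on this read-out lower numbers stand for lower solubility and higher numbers for higher solubility), compound 1 gives 25 ug/mL and compound 3 gives 50 ug/mL in the same pair, and these two values also stand within the scatter of each other. Nothing available bears on the reason for either result.

On these data alone, how an amine or a carboxylic acid at this position would read in the Caco-2 assay or the physicochemical assay remains open. Also open, as far as these compounds go, is whether any group here gives a step beyond the scatter.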